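A few compounds are considered here, and "the series" means these few. Any claim that something is new, unique, unknown or untested is made for them only; others in the source may bear on it.

Measured so far, in a physicochemical assay, at pH 7.4; a higher number here means that the compound lasts longer, a lower number that the compound disappears faster:

Compound 1 `CO[C@H]1C(=O)N2C(C(=O)C(C)(C)C)=C(C)[C@@H](Sc3nc(=O)c(=O)[nH]n3C)S(=O)(=O)C12`: 21 h
Compound 2 `CO[C@H]1C(=O)N2C(C(=O)C(C)(C)C)=C(C)[C@@H](OC=O)S(=O)(=O)C12`: the assay reports only a limit here, < 0.5 h
Compound 3 `CO[C@H]1C(=O)N2C(C(=O)C(C)(C)C)=C(C)[C@@H](Sc3ccccn3)S(=O)(=O)C12`: 24 h

Compound 3 gives the highest of the two numbers in this assay, but its nearest neighbour is compound 1 and that gap, a 1.1-fold higher number from compound 1 to compound 3 (0.06 log units; within the scatter), is within the scatter, so the two cannot be ranked. The step to compound 4 `CO[C@H]1C(=O)N2C(C(=O)C(C)(C)C)=C(C)[C@@H](S(=O)(=O)c3ccccc3)S(=O)(=O)C12` is phenylsulfonyl in place of (pyridin-2-yl)sulfanyl on a saturated ring carbon.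

For the measured compounds named here, two measured steps touch the same position. Replacing formyloxy by (pyridin-2-yl)sulfanyl gave an at least 48-fold higher number from compound 2 to compound 3 (1.68 log units; beyond the scatter), a large change that rests on the limit at which compound 2 sits (the limit of < 0.5 h in this assay, at which 1 of the 3 values shown sits). Swapping the aromatic ring on the sulfur, from compound 1 to compound 3, changed nothing beyond the scatter. Neither step swaps a sulfanyl for a sulfonyl, so the direction of the new step is not covered by the measured compounds; the carbon-oxygen group of compound 2 is the only non-sulfanyl substituent seen there, and it was short-lived.

Compound 4 is therefore estimated at 8 h, within 1 h to 30 h, a step of a 3.0-fold lower number from compound 3 to compound 4 (0.48 log units; beyond the scatter) that is expected to fall below compound 3 with wide uncertainty.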

Compound 4, half-life: 10 h
The estimate for compound 4 lay 1.3-fold (0.10 log units) below the measured number; measured number inside the range.
By their numbers in this assay, from the lowest: compound 4; then compounds 1 and 3 (each within the scatter of the next). At a limit, below all of these: compound 2.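

For the compounds shown here, this is the first group on this saturated ring carbon that is attached through a sulfonyl rather than a sulfanyl, and in this assay the change has a measurable but limited effect: a 2.4-fold lower number from compound 3 to compound 4 (0.38 log units; beyond the scatter), and a 2.1-fold lower number from compound 1 to compound 4 (0.32 log units; beyond the scatter). Both steps lie beyond the scatter, so the phenylsulfonyl group falls short of both sulfanyl groups shown, even though those two carry quite different aromatic rings. Moving away from a sulfanyl link does not in itself bring the short life seen with formyloxy, with an at least 20-fold higher number from compound 2 to compound 4 (1.30 log units; beyond the scatter), and that step rests on a limit of the assay: the limit of < 0.5 h in this assay, at which 1 of the 4 values shown sits.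

The step to phenylsulfonyl changes both the link and the ring, losing the ring nitrogen, so the compounds shown cannot say which of the two accounts for the drop; a phenylsulfanyl group or a (pyridin-2-yl)sulfonyl group on the same carbon would separate them. Also open, going by these compounds, is whether the sulfonyl link needs an aromatic ring at all, as a methylsulfonyl group would show, and how an amine or a carboxylic acid on the phenyl ring would fare.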